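The source may report more compounds than this note shows. Statements on the series, on what has been measured and on what is new or still open speak of the compounds shown alone.

Measured compounds in a functional assay on PBMC cells (Homo sapiens) for inhibition; a higher number here means a weaker inhibitor, a lower number a stronger inhibitor:
- compound 1 `NC(=O)CC[C@H](N)C(=O)NS(=O)(=O)OC[C@H]1O[C@@H](n2cnc3c(N)ncnc32)[C@H](O)[C@@H]1O`: 800 nM
- compound 2 `CC(C)C[C@H](N)C(=O)NS(=O)(=O)OC[C@H]1O[C@@H](n2cnc3c(N)ncnc32)[C@H](O)[C@@H]1O`: 1100 nM
- compound 3 `CC(C)[C@H](N)C(=O)NS(=O)(=O)OC[C@H]1O[C@@H](n2cnc3c(N)ncnc32)[C@H](O)[C@@H]1O`: 5600 nM

Compound 1 gives the lowest number of the three, but its step to compound 2 a 1.4-fold higher number from compound 1 to compound 2 (0.14 log units; within the scatter) lies within the scatter, so the two cannot be ordered. Compound 3 stands apart: a 7.0-fold higher number from compound 1 to compound 3 (0.85 log units; beyond the scatter) and a 5.1-fold higher number from compound 2 to compound 3 (0.71 log units; beyond the scatter) are both beyond the scatter, and both remove length from the side chain.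

Compound 4 `CSCC[C@H](N)C(=O)NS(=O)(=O)OC[C@H]1O[C@@H](n2cnc3c(N)ncnc32)[C@H](O)[C@@H]1O` has not yet been measured. Its difference from compound 1: methylsulfanyl in place of carbamoyl on a saturated chain carbon, three bonds along the chain from an amine nitrogen and a carbonyl carbon

The chain length of compound 1 is kept; only the terminal group changes. The step that bears most on this is a 1.4-fold higher number from compound 1 to compound 2 (0.14 log units; within the scatter), where the carbamoylmethyl group was exchanged for a group of similar size without a shift beyond the scatter. The steps to compound 3 are of a different kind, as they shorten the chain, so they argue little here. The expected step for compound 4 is therefore small, a 1.3-fold higher number from compound 1 to compound 4 (0.10 log units; within the scatter), with no confident direction. Compound 4 is estimated at 1000 nM in this assay, within 400 nM to 2500 nM.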

Compound 4, half-maximal inhibitory concentration: 500 nM
Compound 4: middle estimate off by 2.0-fold (0.30 log units), on the high side, and the stated range covers the measured number.
By their numbers in this assay, from the lowest: compounds 4, 1 and 2 (each within the scatter of the next, the first and the last beyond it); then compound 3.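

In this assay, methylsulfanyl in place of carbamoyl at this position gives a 1.6-fold lower number from compound 1 to compound 4 (0.20 log units; within the scatter) and so shows no shift beyond the scatter, even though the entering group has no hydrogen-bond donor and no double bond. The same side chain separates from the branched groups, with a 2.2-fold lower number from compound 2 to compound 4 (0.34 log units; beyond the scatter) and an 11-fold lower number from compound 3 to compound 4 (1.05 log units; beyond the scatter) both beyond the scatter, whereas compound 1 and compound 2 could not be ordered. No supporting measurement accounts for these steps.

From the compounds shown here alone, it remains open whether the sulfur itself matters, which an all-carbon n-butyl chain would test, and whether a longer chain is tolerated. Going by these compounds, the effect of a carboxylic acid or an amine at the end of this chain also remains open.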